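The compounds below may be only part of what the source reports. "The series", "measured", "known", "first", "only" and "open" are said of these compounds alone.

Going by the values given here, compound 1, with the structure `O=C1O[C@H]([C@@H](O)Cn2cc(-c3ccc(Br)cc3)nn2)C(OCc2ccccc2)=C1OCc1ccccc1`, is the one compound in this set for which a number is known. In a functional assay on SW-620 cells (Homo sapiens) for antiproliferative activity, read by MTT assay, with a stated time of 72 h (on this read-out lower numbers stand for stronger inhibition and higher numbers for weaker inhibition), compound 1 gives 3760 nM, and this is the only number shown. Compound 2, with the structure `CC(C)(C)OC(=O)N1CCN(C(=S)SCc2cn(C[C@H](O)[C@H]3OC(=O)C(OCc4ccccc4)=C3OCc3ccccc3)nn2)CC1`, does not yield a number in this assay: for compound 2 the read-out is > 100000 nM, which is a limit of the assay and not a measurement, and it is described by the limit of > 100000 nM in this assay, at which 1 of the 2 values shown sits.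

Compound 3, with the structure `C[Si](C)(C)c1cn(C[C@H](O)[C@H]2OC(=O)C(OCc3ccccc3)=C2OCc2ccccc2)nn1`, is not yet measured in this assay. It differs from compound 1 in one place: a group of 4 heavy atoms (3 carbon, 1 silicon; no ring) in place of a group of 7 heavy atoms (6 carbon, 1 bromine; one six-membered aromatic ring of carbon only), on an aromatic carbon. No step between two measured compounds is shown for this change, so its size is not known from the set. The author expects compound 3 to be weaker than compound 1 in this assay, with a step of a 3.2-fold higher number from compound 1 to compound 3 (0.50 log units; beyond the scatter) that reaches beyond the usual scatter. For compound 3 the estimate in this assay is 12000 nM, with a range from 3500 nM to 45000 nM.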

Compound 3, half-maximal inhibitory concentration: 56000 nM
Beside the measured number, compound 3's estimate is 4.7-fold (0.67 log units) below it; measured number outside the range, above it.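

On the aromatic carbon of the five-membered aromatic ring with 3 nitrogen, exchanging 4-bromophenyl for the silicon-bearing group with no ring gives a 15-fold higher number from compound 1 to compound 3 (1.17 log units; beyond the scatter) in this assay, a large step. Going by these compounds alone, this is the first step that can be read at this position, and it shows that the read-out is not indifferent to what this carbon carries, with the 4-bromophenyl compound holding the lower number of the pair. Nothing measured here ties the size of this step to a property of either group.

A single step cannot separate the part played by the aromatic ring from the part played by the silicon atom, and a plain phenyl or a tert-butyl group on the same carbon would be needed to pull the two apart. The compounds shown also leave open how an amine, a carboxylic acid or a longer chain at this place would read in this assay.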